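Ethyl in place of hydroxyl hydrogen on a second styryl quinolinol

The source may hold more compounds than are shown below. What is called first, only, known or untested is meant among the compounds shown, and "the series" means these compounds.

Three styryl quinolinols have been measured in a physicochemical assay for lipophilicity, read by HPLC; a lower number here means a more polar compound, a higher number a more lipophilic compound. Compound 1 `Oc1ccccc1/C=C/c1ccc2c(Cl)cc(Cl)c(O)c2n1` gives 5.07 in this assay. Compound 2 `CCOc1ccccc1/C=C/c1ccc2c(Cl)cc(Cl)c(O)c2n1` carries the change ethyl in place of hydrogen on an oxygen on an aromatic ring relative to compound 1, and in this assay compound 2 gives 5.67; the step is a number 0.60 log units higher from compound 1 to compound 2 (beyond the scatter). Compound 3 `Oc1ccc(/C=C/c2ccc3c(Cl)cc(Cl)c(O)c3n2)cc1` differs from compound 1 in its core by 4-hydroxyphenyl in place of 2-hydroxyphenyl on a double-bonded chain carbon bound to a double-bonded chain carbon, and in this assay compound 3 gives 5.07, so that the step is no change at the digits printed from compound 1 to compound 3 (within the scatter).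

Compound 4 `CCOc1ccc(/C=C/c2ccc3c(Cl)cc(Cl)c(O)c3n2)cc1` has not yet been measured in this assay. It differs from compound 3 by ethyl in place of hydrogen on an oxygen on an aromatic ring, which is the same change as that from compound 1 to compound 2, made on a core that differs as described. The expectation therefore rests on compound 3 with its value 5.07 and on the earlier step of a number 0.60 log units higher from compound 1 to compound 2 (beyond the scatter). The step from compound 3 to compound 4 is estimated at a number 0.60 log units higher from compound 3 to compound 4 (beyond the scatter), beside the earlier step. Compound 4 is accordingly expected to give 5.67 in this assay, with a likely range from 5.35 to 6, pending the measurement.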

Compound 4, partition coefficient: 5.67
The estimate for compound 4 equals the measured number at the digits printed, and the stated range covers the measured number.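

In this assay, putting ethyl in place of hydrogen on an oxygen on an aromatic ring gives a number 0.60 log units higher from compound 3 to compound 4 (beyond the scatter) and, on the other core, a number 0.60 log units higher from compound 1 to compound 2 (beyond the scatter) as well, so the step reads the same on both at the digits printed. This shows that the hydroxy to ethoxy change carried over from one core to the other in this series with its size intact, but it rests on a single pair of cores and does not show that the step would hold on any further core. Nothing measured here says why the two steps agree.

The compounds shown leave open whether a longer chain such as butyl on the same oxygen would extend the step or whether it would stop growing. They also leave open what an amine or a carboxylic acid carried at that place would do to the reading.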